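A few compounds are considered here, and "the series" means these few. Any claim that something is new, unique, unknown or untested is made for them only; others in the source may bear on it.

Three compounds share one core and differ only in the ring attached to the aromatic nitrogen. Compound 1 `CNC(=O)c1cc(Oc2ccc(NC(=O)c3cc4cccnc4n(-c4ccccc4)c3=O)cc2)ccn1` gives 250 nM in a functional assay on HT-29 cells (Homo sapiens) for antiproliferative activity, read by MTT assay, with a stated time of 72 h; a higher number here means a weaker inhibitor, a lower number a stronger inhibitor. Compound 2 `CNC(=O)c1cc(Oc2ccc(NC(=O)c3cc4cccnc4n(-c4ccccc4F)c3=O)cc2)ccn1`, carrying a fluoro on that ring, gives 260 nM in this assay, and the step of a 1.0-fold higher number from compound 1 to compound 2 (0.02 log units; within the scatter). Compound 3 `CNC(=O)c1cc(Oc2ccc(NC(=O)c3cc4cccnc4n(-c4ccc(F)cc4)c3=O)cc2)ccn1`, carrying the fluoro elsewhere on the same ring, gives 160 nM in this assay, with a 1.6-fold lower number from compound 1 to compound 3 (0.19 log units; within the scatter) and a 1.6-fold lower number from compound 2 to compound 3 (0.21 log units; within the scatter). Compound 3 thus shows the smallest of the three numbers, yet both steps to it are within the scatter, so the three compounds cannot be separated.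

Compound 4 `CNC(=O)c1cc(Oc2ccc(NC(=O)c3cc4cccnc4n(-c4ccc(Cl)cc4)c3=O)cc2)ccn1` differs from compound 3 by chloro in place of fluoro on an aromatic carbon. For the measured compounds named here, no measured step swaps one halogen for another; the only steps that bear on this position, compound 1 to compound 3 and compound 2 to compound 3, were within the scatter. A step of a 1.1-fold lower number from compound 3 to compound 4 (0.03 log units; within the scatter) is therefore expected, that is, nothing beyond the scatter. Compound 4 is estimated at 150 nM in this assay, in a range from 60 nM to 400 nM.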

Compound 4, half-maximal inhibitory concentration: 390 nM
The estimate for compound 4 lay 2.6-fold (0.41 log units) below the measured number; the measured number falls inside the stated range.
By their numbers in this assay, from the lowest: compounds 3, 1, 2 and 4 (each within the scatter of the next, the first and the last beyond it).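

In this assay, this position turns out to respond to a small change: swapping one halogen for the other gives a 2.4-fold higher number from compound 3 to compound 4 (0.39 log units; beyond the scatter), a modest step but, unlike the earlier fluoro steps, one beyond the scatter. The separation holds only for this pair, as the steps to compound 4 from the other two compounds, a 1.6-fold higher number from compound 1 to compound 4 (0.19 log units; within the scatter) and a 1.5-fold higher number from compound 2 to compound 4 (0.18 log units; within the scatter), stay within the scatter, so chloro does not set compound 4 apart from the unsubstituted phenyl or the 2-fluorophenyl compound. Nothing available explains why the 4-fluorophenyl and 4-chlorophenyl compounds differ.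

On these data alone, a single pair of halogens cannot show a trend, so whether bromo would continue the rise remains open. So does the outcome of a methoxy or an amine at this same place.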